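Carboxy in Place of Methylcarbamoyl

The source may report more compounds than this note shows. Statements on the series, on what has been measured and on what is new or still open speak of the compounds shown alone.

Compound 1 `CNC(=O)/C=C/c1ccncc1-c1ccc2cc[nH]c2c1` gives 7680 nM
Compound 2 `COC(=O)/C=C/c1ccncc1-c1ccc2ccccc2c1` gives 4710 nM

Both values come from a functional assay on MDA-MB-231 cells (Homo sapiens) for inhibition, read by sulforhodamine B assay, with a stated time of 72 h; a lower number here means a stronger inhibitor of growth, a higher number a weaker inhibitor of growth. For the measured compounds named here, with compound 1 at 7680 nM and compound 2 at 4710 nM, the two numbers lie within the usual scatter of each other, so compound 1 cannot be ranked against the only other compound measured.

The next compound, compound 3 `O=C(O)/C=C/c1ccncc1-c1ccc2cc[nH]c2c1`, keeps the core of compound 1 and carries hydroxy in place of methylamino on a carbonyl carbon. The side chain thus goes from 2-(methylcarbamoyl)ethenyl to 2-carboxyethenyl. Going by the values given here, no pair of measured compounds shows this change, and compound 2 differs from compound 1 in more than one place, so the data offer no direct guide. The expectation starts from compound 1 at 7680 nM and is a judgement with a wide margin. In this assay, a weaker inhibitor of growth is expected, with an estimated 2.6-fold higher number from compound 1 to compound 3 (0.42 log units; beyond the scatter). For compound 3 the estimated value is 20000 nM, with an expected range from 7000 nM to 60000 nM.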

Compound 3, concentration for 50% growth inhibition: > 10000 nM
Compound 3: only a limit was reported; the forecaster's own chance of this, stated with the estimate: 25%; the middle value is on the limit's open side.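

In this assay compound 3 gives > 10000 nM, which is a limit and not a number. Hydroxy in place of methylamino on the carbonyl carbon gives an at least 1.3-fold higher number from compound 1 to compound 3 (0.11 log units; that floor lies within the scatter), so on the core of compound 1 this change brings no gain in growth inhibition, yet it cannot be said to bring a loss beyond the scatter. This is the first reading of any change at this carbonyl carbon, and it bounds the result from one side only: the limit of > 10000 nM in this assay, at which 1 of the 3 values shown sits.

Going by these compounds, how far compound 3 truly lies from compound 1 remains open, and with it whether swapping the methylcarbamoyl for the carboxy matters at all in this assay. Also open, on these data alone, is how other groups on the same carbonyl carbon would read on this core, such as a plain amino group, a dimethylamino group or a longer alkylamino chain, and whether any of them would move the number away from that of compound 1.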